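The source may hold more compounds than are shown below. What is called first, only, known or untested is meant among the compounds shown, and "the series" means these compounds.

Compound 1 `C=CC1=C(C(=O)NCc2ccc(C)cc2)C(c2ccc(F)cc2)OC1` gives > 100000 nM in a functional assay on HeLa cells (Homo sapiens) for cytotoxicity, read by MTT assay, with a stated time of 24 h; on this read-out lower numbers stand for stronger inhibition and higher numbers for weaker inhibition.
Compound 2 `C=CC1=C(C(=O)NCC(C)C)C(c2ccc(Cl)c(Cl)c2)OC1` gives 60100 nM in this assay.
Compound 3 `C=CC1=C(C(=O)NCCCCC)C(c2ccc(OC)cc2)OC1` gives > 100000 nM in this assay.

All three compounds share the same core and differ in the amide substituent and in the aryl group on the ring. The value for compound 1 is a limit of the assay and not a number: the cells were not killed to the half-maximal degree at the highest concentration tested. Compound 3 reached the same limit. Compound 2 is the only one of the three that gives a number, and that number is weak. So compound 1 stands at the limit of > 100000 nM in this assay, at which 2 of the 3 values shown sit, with no measured potency of its own.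

Compound 4 `C=CC1=C(C(=O)NCc2ccccc2)C(c2ccc(F)cc2)OC1` has not been measured yet. It differs from compound 1 by hydrogen in place of methyl on an aromatic carbon. Among the measured compounds shown here, no pair of measured compounds shows the effect of this change, so there is nothing to read a direction from. Given that compound 1 already sits at a limit, no step beyond the usual scatter is expected here; the step from compound 1 to compound 4 is estimated as a number no higher from compound 1 to compound 4 (the limit leaves the size open). The estimate for compound 4 in this assay is 100000 nM, expected to fall between 40000 nM and 300000 nM, most likely again reported only as a limit.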

Compound 4, half-maximal inhibitory concentration: > 100000 nM
Compound 4 ended at the assay's limit; the forecaster's own chance of this, stated with the estimate: 70%; the middle value sits exactly at the limit.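

Compound 4 gives > 100000 nM in this assay, which is a limit of the assay and not a number. Compound 1 stands at the same kind of limit, so no step can be read between compound 1 and compound 4: the limit of > 100000 nM in this assay, at which 3 of the 4 values shown sit.

What the compounds shown leave open is whether changing 4-methylbenzyl to benzyl alters potency in this assay at all.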